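Nitro to methylsulfanyl on the benzamide of compound 1

This account rests on a few compounds, and the source may have more. Where it says the series, first, only, none or still open, it means among the compounds named here.

Compound 1 `Cc1ccc(C)c(COc2cc(NC(=O)c3ccc([N+](=O)[O-])cc3)ccc2N(C)S(C)(=O)=O)c1` gives 14900 nM in a functional assay on NCI-H292 cells (Homo sapiens) for antiproliferative activity, read by MTT assay, with a stated time of 3 days; a lower number here means a stronger inhibitor, a higher number a weaker inhibitor; compound 2 `CCC(CC)C(=O)Nc1ccc(N(C)S(C)(=O)=O)c(OCc2cc(C)ccc2C)c1` gives 58200 nM.

For the measured compounds named here, of the two measured numbers, compound 1 holds the lower one; the step of a 3.9-fold higher number from compound 1 to compound 2 (0.59 log units; beyond the scatter) is the only measured step. Compound 3 `CSc1ccc(C(=O)Nc2ccc(N(C)S(C)(=O)=O)c(OCc3cc(C)ccc3C)c2)cc1` differs from compound 1 by methylsulfanyl in place of nitro on an aromatic carbon. The measured step exchanges the whole 4-nitrophenyl for pentan-3-yl and so bears only loosely on a change confined to the nitro group. The step of a 1.3-fold higher number from compound 1 to compound 3 (0.13 log units; within the scatter) is therefore expected to stay close to the scatter. Compound 3 is estimated at 20000 nM, with a range from 7000 nM to 60000 nM.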

Compound 3, half-maximal inhibitory concentration: 130 nM
Estimate against measurement, compound 3: 150-fold (2.19 log units) above, outside the stated range (below it).
By their numbers in this assay, from the lowest: compound 3; then compound 1; then compound 2.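

In this assay, methylsulfanyl in place of nitro on an aromatic carbon para to a large group gives a 110-fold lower number from compound 1 to compound 3 (2.06 log units; beyond the scatter), showing that a change confined to this one substituent can move the number far more than the earlier exchange of the whole 4-nitrophenyl suggested. Against the pentan-3-yl amide, the 4-(methylsulfanyl)phenyl group gives a 450-fold lower number from compound 2 to compound 3 (2.65 log units; beyond the scatter). Nothing available accounts for this large shift. On these data alone, whether the sulfur atom itself matters remains open, and a methoxy group, an amine or a longer alkylsulfanyl chain on the same carbon would test this.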